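Cyclopentylmethyl in place of isopropyl on the ketone

The source may hold more compounds than are shown below. What is called first, only, known or untested is meant among the compounds shown, and "the series" means these compounds.

Compound 1 `Cc1c(OCCCCOc2ccc(C(=O)O)cc2F)ccc(C(=O)CC2CCCC2)c1O`: in an assay on HEK293 cells for positive allosteric modulation of metabotropic glutamate receptor 3 (Rattus norvegicus), read by thallium flux, with a stated time of 2.5 min (a lower number here means that less compound is needed, a higher number that more compound is needed for the effect), compound 1 reaches only the limit > 10000 nM.
Compound 2 `Cc1c(OCCCCOc2ccccc2C(=O)O)ccc(C(=O)CC2CCCC2)c1O`: in this assay compound 2 has "not determined" (no result reported).
Compound 3 `COc1ccc(C(=O)O)cc1OCCCCOc1ccc(C(=O)C(C)C)c(O)c1C`: in this assay compound 3 gives 588 nM.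

Among the measured compounds shown here, compound 3 holds the only number among the three; one further entry is a limit, the other carries no result. The limit of compound 1 is marked by the limit of > 10000 nM in this assay, at which 1 of the 3 values shown sits. Compound 4 `COc1ccc(C(=O)O)cc1OCCCCOc1ccc(C(=O)CC2CCCC2)c(O)c1C` differs from compound 3 in one place: cyclopentylmethyl in place of isopropyl on a carbonyl carbon. For the measured compounds named here, no measured pair shows this exact change, and compound 1, which shares the cyclopentylmethyl ketone, differs from compound 3 in more than one place, so its limit cannot be set against the number of compound 3 as a step. With nothing to lean on, the change is expected to shift this assay little, if at all, beyond the usual scatter, giving an expected step of a 1.0-fold higher number from compound 3 to compound 4 (0.01 log units; within the scatter). Compound 4 is therefore estimated at 600 nM, with a range from 150 nM to 2500 nM.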

Compound 4, half-maximal effective concentration: 1020 nM
Compound 4: the middle estimate sits 1.7-fold (0.23 log units) below what was measured; the measured number falls inside the stated range.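

In this assay, the change on the carbonyl carbon now has a direct reading: a 1.7-fold higher number from compound 3 to compound 4 (0.24 log units; within the scatter), so cyclopentylmethyl and isopropyl are not told apart here. Among the compounds shown here, with the cyclopentylmethyl ketone held fixed, the change on the oxygen on a saturated carbon, 5-carboxy-2-methoxyphenyl in place of 4-carboxy-2-fluorophenyl, is the one that carries a step beyond the scatter: an at least 9.8-fold lower number from compound 1 to compound 4 (0.99 log units; beyond the scatter). The entry for compound 1 in that step is a limit, not a number: the limit of > 10000 nM in this assay, at which 1 of the 4 values shown sits.

The compounds shown leave open how a longer chain or a cyclohexylmethyl group on the ketone would read. They also leave open whether a tetrazole or an amide in place of the carboxylic acid would keep a measurable value in this assay.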